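This account rests on a few compounds, and the source may have more. Where it says the series, first, only, none or still open, it means among the compounds named here.

Compound 1 `CCCCCCCCCCCCCCCCCCNC(=O)[C@H]1CSC(c2ccc(N(C)C)cc2)N1` and compound 2 `CCCCCCCCCCCCCCCCCCNC(=O)[C@H]1CSC(c2cc(F)cc(F)c2)N1` share one core and differ only in the aromatic group on a saturated ring carbon. In a functional assay on PPC-1 cells (Homo sapiens) for antiproliferative activity, read by sulforhodamine B assay (on this read-out lower numbers stand for stronger inhibition and higher numbers for weaker inhibition), compound 1 gives 1100 nM, while compound 2 gives 10600 nM. For the measured compounds named here, the step of a 9.6-fold higher number from compound 1 to compound 2 (0.98 log units; beyond the scatter) is the only comparison so far, and compound 2 stands at the higher, weaker end of the two numbers.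

Compound 3 `CCCCCCCCCCCCCCCCCCNC(=O)[C@H]1CSC(c2ccc(C)cc2)N1` is not yet measured. Its change from compound 2 is 4-methylphenyl in place of 3,5-difluorophenyl on a saturated ring carbon. Going by the values given here, the one measured step that bears on this place, a 9.6-fold higher number from compound 1 to compound 2 (0.98 log units; beyond the scatter), shows that the group on this carbon can move the number by a large margin. A 4-methylphenyl is neither of the two groups already seen, so the expected step of a 3.0-fold lower number from compound 2 to compound 3 (0.48 log units; beyond the scatter) is placed between them, toward a lower number. For compound 3 in this assay the estimate is 3500 nM, expected to fall between 1000 nM and 12000 nM.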

Compound 3, half-maximal inhibitory concentration: 1900 nM
Beside the measured number, compound 3's estimate is 1.8-fold (0.27 log units) above it, within the range that was stated.
By their numbers in this assay, from the lowest: compounds 1 and 3 (each within the scatter of the next); then compound 2.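

In this assay, 4-methylphenyl on this saturated ring carbon gives a 5.6-fold lower number from compound 2 to compound 3 (0.75 log units; beyond the scatter) and so shows that a second group, carrying only carbon on its ring, also stands clearly apart from 3,5-difluorophenyl. Methyl in place of dimethylamino on an aromatic carbon gives a 1.7-fold higher number from compound 1 to compound 3 (0.24 log units; within the scatter) and so, unlike the first comparison, shows a change of group at this position that stays within the scatter; the nitrogen of dimethylamino is therefore not required for a number of this size. Nothing available here explains these differences.

The compounds shown leave open whether the gap to compound 2 follows the fluorine atoms or the places they occupy on the ring. A 4-fluorophenyl or a 3,5-dimethylphenyl group on this carbon would separate those two readings.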